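Carboxy to carbamoyl: what compound 3 may show

A few compounds are considered here, and "the series" means these few. Any claim that something is new, unique, unknown or untested is made for them only; others in the source may bear on it.

In a functional assay on A2780 cells (Homo sapiens) for inhibition (on this read-out higher numbers stand for weaker inhibition and lower numbers for stronger inhibition), compound 2 (`CCNC(=O)c1noc(-c2cc(C(C)C)c(O)cc2O)c1-c1cc(C(=O)O)no1`) gives 20000 nM, the higher of the two numbers, while compound 1 (`CCNC(=O)c1noc(-c2cc(C(C)C)c(O)cc2O)c1-c1cc(CN(C)C)no1`) gives 31 nM. Compound 3 (`CCNC(=O)c1noc(-c2cc(C(C)C)c(O)cc2O)c1-c1cc(C(N)=O)no1`), not yet measured, differs from compound 2 by amino in place of hydroxy on a carbonyl carbon. For the measured compounds named here, the one measured step bearing on this, a 650-fold higher number from compound 1 to compound 2 (2.81 log units; beyond the scatter), is large and ends at the same carboxy group, though it is a different change. A large move to a lower number in this assay is therefore expected, regaining only part of that step. The expected change is a 50-fold lower number from compound 2 to compound 3 (1.70 log units; beyond the scatter). For compound 3 the estimate is 400 nM, with an expected range of 80 nM to 2500 nM.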

Compound 3, half-maximal inhibitory concentration: 15 nM
For compound 3 the middle estimate is 27-fold (1.43 log units) above the measured one; the measured number lies below the stated range.
By their numbers in this assay, from the lowest: compound 3; then compound 1; then compound 2.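

In this assay the exchange of hydroxy for amino on the carbonyl carbon gives a 1300-fold lower number from compound 2 to compound 3 (3.12 log units; beyond the scatter), so one atom at this position spans the whole range of numbers seen so far. Carbamoyl also gives a 2.1-fold lower number from compound 1 to compound 3 (0.32 log units; beyond the scatter), which shows that a low number here does not require the amine of (dimethylamino)methyl. No evidence is available to explain the gap between carboxy and carbamoyl. From the compounds shown here alone, it remains open whether a methyl ester, a nitrile or a methylamide at this position would keep the number low.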